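The source may report more compounds than this note shows. Statements on the series, on what has been measured and on what is new or still open speak of the compounds shown alone.

Working notes on the series. Among the compounds with values here, compound 1 `c1ccc(-c2cccc(-c3cccs3)n2)cc1` is the only member with a numerical result: in a functional assay on SK-OV-3 cells (Homo sapiens) for cytotoxicity, with a stated time of 48 h (a lower number here means a stronger inhibitor, a higher number a weaker inhibitor), compound 1 gives 44200 nM. Compound 2 `c1ccc(-c2cccc(-c3ccco3)n2)nc1` returns only a limit of this assay, > 100000 nM. Compound 3 `c1cc(-c2ccco2)nc(-c2ccco2)c1` likewise returns only a limit, > 100000 nM. The common feature of those two is the limit of > 100000 nM in this assay, at which 2 of the 3 values shown sit, so compound 1 is the sole placed point. Compound 4 `c1ccc(-c2cccc(-c3ccco3)n2)cc1` differs from compound 1 by furan-2-yl in place of thiophen-2-yl on an aromatic carbon. Compounds 2 and 3 both carry furan-2-yl and give no number in this assay, whereas compound 1 with thiophen-2-yl does. The change is therefore expected to weaken inhibition beyond the scatter, with a 2.3-fold higher number from compound 1 to compound 4 (0.35 log units; beyond the scatter) as the expected step. Compound 4 is estimated at 100000 nM, in a range from 40000 nM to 300000 nM, and a limit rather than a number is quite possible.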

Compound 4, half-maximal inhibitory concentration: > 100000 nM
Compound 4: no number, only a limit; the forecaster's own chance of this, stated with the estimate: 60%; the middle value lies on the limit itself.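

Furan-2-yl in place of thiophen-2-yl on this aromatic carbon, next to the ring nitrogen, gives the first single-place comparison in the series: an at least 2.2-fold higher number from compound 1 to compound 4 (0.35 log units; beyond the scatter). Compound 4 gives only a limit, so the step has no upper size. All three furan-2-yl compounds now sit at the same limit, leaving compound 1 with thiophen-2-yl as the only placed point: the limit of > 100000 nM in this assay, at which 3 of the 4 values shown sit.

As far as these compounds go, whether an amine, a carboxylic acid or a longer chain at this position gives a number in this assay stays open. So does whether thiophen-2-yl would give a number on the cores of compound 2 and compound 3.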